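A few compounds are considered here, and "the series" means these few. Any claim that something is new, unique, unknown or untested is made for them only; others in the source may bear on it.

Among the compounds with values here, compound 2 `c1ccc2c(c1)CC2CCCN1CCN(c2cccc3c2OCCO3)CC1` is the only compound of the pair whose result in a functional assay on the whole organism for agonist activity, with Rattus norvegicus as the target (on this read-out higher numbers stand for an effect only at larger amounts of compound and lower numbers for an effect already at smaller amounts), is a number: in this assay compound 2 gives 10 mg/kg. Its neighbour compound 1 `c1ccc2c(c1)CC2CCCCN1CCN(c2cccc3c2OCCO3)CC1` differs from it only in the length of the chain, and in this assay compound 1 gives > 10 mg/kg, which is a limit of the assay and not a number. Within the data shown here, the one measured step, a number no higher from compound 1 to compound 2 (the limit leaves the size open), therefore cannot be read for size, as it rests on (the limit of > 10 mg/kg in this assay, at which 1 of the 2 values shown sits). Compound 3 `c1ccc2c(c1)CC(CCCN1CCN(c3cccc4c3OCCO4)CC1)C2` has not been measured yet. It differs from compound 2 at the end of the chain: a group of 9 heavy atoms (9 carbon; one five-membered non-aromatic ring of carbon only, one six-membered aromatic ring of carbon only) in place of a group of 8 heavy atoms (8 carbon; one four-membered non-aromatic ring of carbon only, one six-membered aromatic ring of carbon only), on a saturated chain carbon, three bonds along the chain from an amine nitrogen in a ring. Among the measured compounds shown here, no measured step alters that group; the only recorded step changes the chain and leaves its size open, so nothing in the data argues for a shift in either direction beyond the scatter. The step from compound 2 to compound 3 is expected to be no change at the digits printed from compound 2 to compound 3 (within the scatter). Compound 3 is thus estimated at 10 mg/kg in this assay, expected to fall between 3 mg/kg and 30 mg/kg.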

Compound 3, minimum effective dose: 40 mg/kg
Compound 3: the middle estimate sits 4.0-fold (0.60 log units) below what was measured; the measured number lies above the stated range.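

In this assay the group at the end of the chain turns out not to be indifferent: a 4.0-fold higher number from compound 2 to compound 3 (0.60 log units; beyond the scatter). Within the data shown here, this is the first step whose size can be read, and it comes from placing 2,3-dihydro-1H-inden-2-yl, with its five-membered carbon ring, where compound 2 has its four-membered carbon ring, on a saturated chain carbon, three bonds along the chain from an amine nitrogen in a ring. The steps that involve compound 1 cannot be read for size, and the reason lies in a limit, which is not a number: the limit of > 10 mg/kg in this assay, at which 1 of the 3 values shown sits.

The compounds shown leave open why this ring change moves the number, since they give a single pair that differs in this group and no measured property that could account for it. They also leave open how a phenyl or cyclohexyl group would read at this place, and whether 2,3-dihydro-1H-inden-2-yl on a shorter or a longer chain would follow compound 3.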